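Adding a pentyl group to compound 2

A few compounds are considered here, and "the series" means these few. Any claim that something is new, unique, unknown or untested is made for them only; others in the source may bear on it.

Compound 1 `CC(CCO)n1cnc2c(Cl)nc(F)nc21`: 19800 nM
Compound 2 `CC(CCO)n1cnc2c(Cl)ncnc21`: > 50000 nM
Compound 3 `C=C(CO)C(CCCCC)n1cnc2c(Cl)ncnc21`: > 50000 nM

In a functional assay on HCT-116 cells (Homo sapiens) for antiproliferative activity, read by MTT assay, with a stated time of 48 h (a lower number here means a stronger inhibitor, a higher number a weaker inhibitor), compound 2 gives > 50000 nM, which is a limit and not a number. Compound 3 gives > 50000 nM, also a limit. Only compound 1 gives a number, 19800 nM.

Compound 4 `CCCCCCC(CCO)n1cnc2c(Cl)ncnc21` departs from compound 2 by pentyl in place of hydrogen on a saturated chain carbon, two bonds along the chain from an aromatic nitrogen. Among the measured compounds shown here, the one measured step, an at least 2.5-fold higher number from compound 1 to compound 2 (0.40 log units; beyond the scatter), is a different change and bears only indirectly on this one. Compound 3, which also carries a pentyl group, sits at the limit of > 50000 nM, so only a modest move towards a lower number in this assay is expected. The expected step is an at least 1.2-fold lower number from compound 2 to compound 4 (0.09 log units; that floor lies within the scatter). For compound 4 the estimate is 40000 nM, with an expected range of 15000 nM to 100000 nM.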

Compound 4, half-maximal inhibitory concentration: 11900 nM
Compound 4: middle estimate off by 3.4-fold (0.53 log units), on the high side; the whole stated range lies above it.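

In this assay, pentyl in place of hydrogen on a saturated chain carbon, two bonds along the chain from an aromatic nitrogen, gives an at least 4.2-fold lower number from compound 2 to compound 4 (0.62 log units; beyond the scatter), so this position tolerates a chain and the change yields a measured value. A pentyl group alone does not ensure this: compound 3 gives > 50000 nM, which is a limit. The step is only a floor, because compound 2 itself stands at a limit: the limit of > 50000 nM in this assay, at which 2 of the 4 values shown sit.

As far as these compounds go, whether a longer chain, or a chain ending in an amine, would lower the number further remains open. So does whether pentyl has the same effect on compound 1, which carries fluoro.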